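The source may report more compounds than this note shows. Statements on the series, on what has been measured and on what is new or still open speak of the compounds shown alone.

Compound 1 `N#Cc1cnc(NCc2cnccc2C(F)(F)F)cc1NC[C@H]1C[C@@H](O)C1` and compound 2 `N#Cc1cnc(NCc2cnccc2C(F)(F)F)cc1N[C@H]1CC[C@@H](O)CC1` share a core and differ only in the group on one ring nitrogen. In an assay on isolated protein for inhibition of protein kinase C delta type (Homo sapiens), read by TR-FRET, with a stated time of 2 h (a lower number here means a stronger inhibitor, a higher number a weaker inhibitor), compound 1 gives 4200 nM. In this assay compound 2 gives 4500 nM, and the step of a 1.1-fold higher number from compound 1 to compound 2 (0.03 log units; within the scatter) stays within the scatter. Compound 3 `CO[C@H]1CC[C@H](Nc2cc(NCc3cnccc3C(F)(F)F)ncc2C#N)CC1` carries a methoxy group on the cyclohexyl ring instead of a hydroxyl. In this assay compound 3 reaches only the limit of the assay, > 10000 nM, so it sits at the limit of > 10000 nM in this assay, at which 1 of the 3 values shown sits, and no exact number is known for it. The steps of an at least 2.3-fold higher number from compound 1 to compound 3 (0.37 log units; beyond the scatter) and an at least 2.2-fold higher number from compound 2 to compound 3 (0.34 log units; beyond the scatter) both run to a weaker value at that limit.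

Compound 4 `N#Cc1cnc(NCc2cnccc2C(F)(F)F)cc1NC[C@H]1CC[C@H](O)CC1` is now to be measured in this assay. Its change from compound 3 is (4-hydroxycyclohexyl)methyl in place of 4-methoxycyclohexyl on a nitrogen on an aromatic ring, so a hydroxyl returns, as in compound 1 and compound 2. Both of those compounds gave numbers below the limit, so compound 4 is expected to give a lower number than compound 3, with the step of an at least 2.2-fold lower number from compound 3 to compound 4 (0.34 log units; beyond the scatter) estimated to run back toward the range of compound 1 and compound 2. Compound 4 is therefore estimated at 4500 nM, with a range from 1800 nM to 11000 nM.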

Compound 4, half-maximal inhibitory concentration: 2000 nM
Compound 4: middle estimate off by 2.3-fold (0.35 log units), on the high side; low and high end bracket the measured number.
By their numbers in this assay, from the lowest: compound 4; then compounds 1 and 2 (each within the scatter of the next). At a limit, above all of these: compound 3.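

In this assay, with the cyclohexyl ring and its hydroxyl kept, (4-hydroxycyclohexyl)methyl in place of 4-hydroxycyclohexyl gives a 2.3-fold lower number from compound 2 to compound 4 (0.35 log units; beyond the scatter), so a change on this nitrogen among the hydroxyl-bearing compounds now goes beyond the scatter. With the saturated chain carbon kept, 4-hydroxycyclohexyl in place of 3-hydroxycyclobutyl gives a 2.1-fold lower number from compound 1 to compound 4 (0.32 log units; beyond the scatter), so the ring on that chain also changes the number modestly. The step of an at least 5.0-fold lower number from compound 3 to compound 4 (0.69 log units; beyond the scatter) is only a bound, since compound 3 stands at a limit of the assay and not at a number: the limit of > 10000 nM in this assay, at which 1 of the 4 values shown sits.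

That step changes the methoxy group to a hydroxyl and also moves the ring out by a chain carbon, and the compounds shown do not separate these two changes. From the compounds shown here alone, whether an amine in place of the hydroxyl, or a longer chain on the nitrogen, would lower the number further stays open.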